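The source may report more compounds than this note shows. Statements on the series, on what has been measured and on what is new or still open speak of the compounds shown alone.

Measured so far:
compound 1 `COCc1cc(=O)oc2cc(O)ccc12` — in an assay on HeLa cells for inhibition of 17-beta-hydroxysteroid dehydrogenase type 3 (Homo sapiens) (a higher number here means a weaker inhibitor, a lower number a stronger inhibitor), compound 1 gives 5000 nM
compound 2 `O=c1cc(CSc2ncccn2)c2ccc(O)cc2o1` — compound 2 gives 1000 nM
compound 3 `O=c1cc(CSc2nncs2)c2ccc(O)cc2o1` — compound 3 gives 200 nM

Compound 3 stands lowest of the three numbers: both a 25-fold lower number from compound 1 to compound 3 (1.40 log units; beyond the scatter) and a 5.0-fold lower number from compound 2 to compound 3 (0.70 log units; beyond the scatter) are beyond the scatter. Compound 4 `Cn1ccnc1SCc1cc(=O)oc2cc(O)ccc12` differs from compound 3 by 1-methyl-1H-imidazol-2-yl in place of 1,3,4-thiadiazol-2-yl on a sulfur. Of the measured steps, only the exchange of the ring on the sulfur bears on this change, and that step, a 5.0-fold lower number from compound 2 to compound 3 (0.70 log units; beyond the scatter), was modest; the large step of a 25-fold lower number from compound 1 to compound 3 (1.40 log units; beyond the scatter) concerns a different change and gives no guidance here. The exchange of one five-membered aromatic ring for another is therefore expected to cost something, but less than a return to compound 2, so a modest upward step a 2.5-fold higher number from compound 3 to compound 4 (0.40 log units; beyond the scatter) is expected. Compound 4 is estimated at 500 nM in this assay, with a range of 150 nM to 2000 nM.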

Compound 4, half-maximal inhibitory concentration: 91 nM
Compound 4: the middle estimate sits 5.5-fold (0.74 log units) above what was measured; measured number outside the range, below it.
By their numbers in this assay, from the lowest: compound 4; then compound 3; then compound 2; then compound 1.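

On the sulfur bound to the saturated chain carbon, 1-methyl-1H-imidazol-2-yl in place of 1,3,4-thiadiazol-2-yl gives a 2.2-fold lower number from compound 3 to compound 4 (0.34 log units; beyond the scatter) in this assay, so the previous best ring here is not the limit. In place of pyrimidin-2-yl, the same group gives an 11-fold lower number from compound 2 to compound 4 (1.04 log units; beyond the scatter), and a five-membered aromatic ring with 2 hetero atoms now ranks ahead of the one with 3. No measurement available here accounts for this gain. Open, going by these compounds, is whether the gain follows the ring or its methyl, a question that 1H-imidazol-2-yl and 1-ethyl-1H-imidazol-2-yl on this sulfur would address.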